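The compounds below may be only part of what the source reports. "The series", "measured", "known", "first", "only" and "open" are said of these compounds alone.

Working notes on the amide series in a physicochemical assay for solubility, read by spectrophotometry, measured as kinetic solubility, at pH 8, tested at 500 uM; a higher number here means a more soluble compound, a lower number a less soluble compound. Compound 1 (`CN(C)C(=O)c1ccncc1Nc1cc(-c2ccc3ccn(C)c3c2)c2nccnc2c1`) gives 175 ug/mL, compound 2 (`CN1CCC(NC(=O)c2ccncc2Nc2cc(-c3ccc4ccn(C)c4c3)c3nccnc3c2)CC1`) gives 246 ug/mL and compound 3 (`CC(=O)N1CCCC(NC(=O)c2ccncc2Nc2cc(-c3ccc4ccn(C)c4c3)c3nccnc3c2)C1`) gives 212 ug/mL. These three numbers lie within the scatter of one another, so compound 3 holds no real rank among them. Compound 4 (`CN1CC(NC(=O)c2ccncc2Nc2cc(-c3ccc4ccn(C)c4c3)c3nccnc3c2)CCC1=O`) carries 1-methyl-6-oxopiperidin-3-yl in place of 1-acetylpiperidin-3-yl on the amide-type nitrogen: 1-methyl-6-oxopiperidin-3-yl in place of 1-acetylpiperidin-3-yl on an amide-type nitrogen. The nearest measured evidence is a 1.2-fold higher number from compound 1 to compound 3 (0.08 log units; within the scatter) and a 1.2-fold lower number from compound 2 to compound 3 (0.06 log units; within the scatter), alongside a 1.4-fold higher number from compound 1 to compound 2 (0.15 log units; within the scatter). All three changes at this position stayed within the scatter, so no step beyond the scatter is expected in this assay. The expected change is a 1.0-fold lower number from compound 3 to compound 4 (0.00 log units; within the scatter). For compound 4 the estimated value is 210 ug/mL, with an expected range of 125 ug/mL to 265 ug/mL.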

Compound 4, solubility: 253 ug/mL
Beside the measured number, compound 4's estimate is 1.2-fold (0.08 log units) below it, and the stated range covers the measured number.
By their numbers in this assay, from the lowest: compounds 1, 3, 2 and 4 (each within the scatter of the next).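

In this assay, 1-methyl-6-oxopiperidin-3-yl in place of 1-acetylpiperidin-3-yl on the amide-type nitrogen gives a step within the scatter (a 1.2-fold higher number from compound 3 to compound 4 (0.08 log units; within the scatter)), and the same holds against the two other groups (a 1.0-fold higher number from compound 2 to compound 4 (0.01 log units; within the scatter)) (a 1.4-fold higher number from compound 1 to compound 4 (0.16 log units; within the scatter)). Across four groups, this position has therefore shown no step beyond the scatter, now including a carbonyl inside the six-membered ring. Nothing available accounts for these numbers. On these data alone, whether a carboxylic acid or a longer chain carrying a primary amine at this position would give a step beyond the scatter stays open.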